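Replacing 4-methylphenyl with 1-methyl-1H-indol-3-yl

This account rests on a few compounds, and the source may have more. Where it says the series, first, only, none or still open, it means among the compounds named here.

Measured in a functional assay on MCF7 cells (Homo sapiens) for inhibition, read by CCK-8 assay, with a stated time of 48 h; on this read-out higher numbers stand for weaker inhibition and lower numbers for stronger inhibition:
- compound 1 `COc1cc(-c2cc3nccc(-c4cc(OC)c(OC)c(OC)c4)n3n2)cc(OC)c1OC`: > 10000 nM (a limit of the assay)
- compound 2 `COc1cc(-c2ccnc3cc(-c4ccc(C)cc4)nn23)cc(OC)c1OC`: 47 nM
- compound 3 `Cn1ccc2cc(-c3cc4nccc(-c5ccc(F)cc5)n4n3)ccc21`: 4580 nM

Only two of these three results are actual numbers. Compound 1 stands at > 10000 nM, which is a limit and not a number. Compound 2 gives 47 nM, the lower of the two numbers, while compound 3 gives 4580 nM, and this gap lies well beyond the usual scatter.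

The next compound to be tested is compound 4 `COc1cc(-c2ccnc3cc(-c4cn(C)c5ccccc45)nn23)cc(OC)c1OC`. It keeps the rest of compound 2 but carries 1-methyl-1H-indol-3-yl in place of 4-methylphenyl on an aromatic carbon of a five-membered aromatic ring with 2 nitrogen (1-methyl-1H-indol-3-yl in place of 4-methylphenyl on an aromatic carbon).

For the measured compounds named here, no two measured compounds differ in one place alone, so no measured step shows what such an exchange does. Compound 3 differs from compound 2 in more than one place and offers no direct guide. The starting point is therefore compound 2 at 47 nM, and no large shift is expected in this assay. The expected change a 1.2-fold lower number from compound 2 to compound 4 (0.07 log units; within the scatter) is estimated to stay within the usual scatter, with no firm direction. For compound 4 the value is estimated at 40 nM, with an expected range from 6 nM to 400 nM.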

Compound 4, half-maximal inhibitory concentration: 95 nM
For compound 4 the middle estimate is 2.4-fold (0.38 log units) below the measured one; measured number inside the range.
By their numbers in this assay, from the lowest: compound 2; then compound 4; then compound 3. At a limit, above all of these: compound 1.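

In this assay, for the compounds shown here, the exchange of 4-methylphenyl for 1-methyl-1H-indol-3-yl gives the first step in this set that changes one place alone: a 2.0-fold higher number from compound 2 to compound 4 (0.31 log units; beyond the scatter), a modest change. It shows that this aromatic carbon of the five-membered aromatic ring with 2 nitrogen accepts a group of 10 heavy atoms instead of 7, with a second aromatic ring and a ring nitrogen, at the cost of only this modest rise, and compound 4 still gives 95 nM. Nothing measured here bears on why the number rises, so the step records the size of the change and gives no reason for it.

With a single step at this position, the compounds shown leave open whether the rise comes from the larger ring system or from the methyl on its nitrogen, which the unmethylated 1H-indol-3-yl group would help to separate. They also leave open how the position responds to a group of a different kind, such as a morpholine, a carboxylic acid or a longer alkyl chain, in place of an aromatic ring.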